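Series notes: substituent on the aromatic nitrogen, step to compound 4

A few compounds are considered here, and "the series" means these few. Any claim that something is new, unique, unknown or untested is made for them only; others in the source may bear on it.

Measured so far:
compound 1 `CCCn1nc(-c2cccnc2)c2ccccc2c1=O` 86%
compound 2 `CC(C)n1nc(-c2cccnc2)c2ccccc2c1=O` 87%
compound 3 `CC(=O)OCCn1nc(-c2cccnc2)c2ccccc2c1=O` 32%

In an assay on isolated protein (Oryctolagus cuniculus) with Thromboxane-A synthase (Homo sapiens) as the target, tested at 1 uM (on this read-out lower numbers stand for less inhibition and higher numbers for more inhibition at the one concentration tested (going by the name of the read-out)), compound 1 gives 86%, second highest of the three numbers; its nearest neighbour is compound 2 at a number 1 percentage points higher from compound 1 to compound 2 (within the scatter), its furthest compound 3 at a number 54 percentage points lower from compound 1 to compound 3 (beyond the scatter). Compound 4 `NCCn1nc(-c2cccnc2)c2ccccc2c1=O` differs from compound 1 by amino in place of methyl on a saturated chain carbon, two bonds along the chain from an aromatic nitrogen. Among the compounds with values here, the step that bears on this is the one to compound 3, which changes the same chain carbon: a number 54 percentage points lower from compound 1 to compound 3 (beyond the scatter), a large loss. The exchange to compound 2, a number 1 percentage points higher from compound 1 to compound 2 (within the scatter), changes only the chain shape and stays within the scatter. Within the data shown here, a loss beyond the scatter in this assay is therefore expected for compound 4, though possibly smaller than that seen with compound 3, because a number 54 percentage points lower from compound 1 to compound 3 (beyond the scatter) is the only comparable step. The expected step is a number 36 percentage points lower from compound 1 to compound 4 (beyond the scatter). Compound 4 is estimated at 50%, range 25% to 75%.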

Compound 4, a percentage reported as inhibition, at one concentration (the size of the read-out at that concentration, not a potency): 29%
For compound 4 the middle estimate is 21 percentage points above the measured one; measured number inside the range.
By their numbers in this assay, from the lowest: compounds 4 and 3 (each within the scatter of the next); then compounds 1 and 2 (each within the scatter of the next).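

In this assay the amino group falls as far as the acetoxy group at this chain carbon: a number 57 percentage points lower from compound 1 to compound 4 (beyond the scatter) and a number 58 percentage points lower from compound 2 to compound 4 (beyond the scatter), while a number 3 percentage points lower from compound 3 to compound 4 (within the scatter). The large loss is therefore not specific to the acetoxy ester, since two different groups on this carbon both give it. No measurement at hand explains the loss.

Going by these compounds, it remains open whether a hydroxyl, methoxy or carboxylic acid on the same carbon gives a similar loss. A longer unsubstituted chain such as butyl, and a dimethylamino group in place of amino, are also untested here.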